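Nitro Sulfone Amides Stalled at the Assay Ceiling

A few compounds are considered here, and "the series" means these few. Any claim that something is new, unique, unknown or untested is made for them only; others in the source may bear on it.

Three amides sharing a nitro-bearing core were tested in an assay on isolated protein for inhibition of thyroid hormone receptor beta (Homo sapiens), read by fluorescence polarization; on this read-out higher numbers stand for weaker inhibition and lower numbers for stronger inhibition. Compound 1 `CS(=O)(=O)c1ccc(C(=O)N2CCC(C(=O)N3CCN(c4ccc(F)cc4)CC3)CC2)cc1[N+](=O)[O-]` gives > 60000 nM, which is a limit of the assay rather than a number. Compound 3 `CS(=O)(=O)c1ccc(C(=O)N2CCC(C(=O)N3CCc4ccccc4C3)CC2)cc1[N+](=O)[O-]` likewise gives > 60000 nM, again only a limit. Compound 2 `CCCN(C(=O)CN(C)C(=O)c1ccc(S(C)(=O)=O)c([N+](=O)[O-])c1)c1ccccc1` stands at the same place, with > 60000 nM as a limit and no measured number at all. Taken together, the picture is the limit of > 60000 nM in this assay, at which 3 of the 3 values shown sit. Compound 4 `CN(Cc1cccc(F)c1)C(=O)CN(C)C(=O)c1ccc(S(C)(=O)=O)c([N+](=O)[O-])c1` has not yet been measured; it differs from compound 2 by (3-fluorobenzyl)(methyl)amino in place of phenyl(propyl)amino on a carbonyl carbon. With every measured neighbour sitting at the limit, no step size can be read off, and the expected step is a step that the limit leaves unreadable from compound 2 to compound 4, that is, nothing beyond the scatter. Compound 4 is therefore estimated at 80000 nM, within 20000 nM to 300000 nM, and most likely reported once more as a limit.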

Compound 4, half-maximal inhibitory concentration: > 60000 nM
Compound 4: only a limit was reported (the forecaster's own chance of this, stated with the estimate: 85%); the middle value lies beyond the limit too.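

Within the data shown here, compound 2 and compound 4 are both reported only as limits, and no step between them can be read. The compounds shown leave open what change to the shared core, if any, would give a measured number instead of a limit.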